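This account rests on a few compounds, and the source may have more. Where it says the series, first, only, none or still open, it means among the compounds named here.

Measured so far:
- compound 1 `O=C(NCCCCC(c1ccc(F)cc1)c1ccc(F)cc1)Nc1ccc(I)cc1`, 11800 nM
- compound 2 `CC(=O)Nc1ccc(NC(=O)NCCCCC(c2ccc(F)cc2)c2ccc(F)cc2)cc1`, > 20000 nM
- compound 3 `Nc1cc(NC(=O)NCCCCC(c2ccc(F)cc2)c2ccc(F)cc2)ccc1Cl`, 9240 nM

All three share one core, a urea linked through a short chain to a carbon bearing two fluorophenyl groups, and differ only in the aromatic group on the other urea nitrogen. In a functional assay on MDA-MB-231 cells (Homo sapiens) for cytotoxicity, read by MTT assay, with a stated time of 48 h (on this read-out higher numbers stand for weaker inhibition and lower numbers for stronger inhibition), compound 1 gives 11800 nM. Compound 2 gives only a limit of the assay, > 20000 nM, so its true value is not known and its position is the weakest that the numbers can show (the limit of > 20000 nM in this assay, at which 1 of the 3 values shown sits). Compound 3 gives 9240 nM. The two steps from compound 2 are an at least 2.1-fold lower number from compound 2 to compound 3 (0.33 log units; beyond the scatter) and, read backwards from compound 1, an at least 1.6-fold higher number from compound 1 to compound 2 (0.22 log units; that floor lies within the scatter).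

Compound 4 `O=C(NCCCCC(c1ccc(F)cc1)c1ccc(F)cc1)Nc1ccc([N+](=O)[O-])c(Cl)c1` changes compound 2 as follows: 3-chloro-4-nitrophenyl in place of 4-acetamidophenyl on an amide-type nitrogen. For the measured compounds named here, the most relevant measured step is the one to compound 3, which also removed the 4-acetamidophenyl in favour of a chlorine-bearing aromatic group and was an at least 2.1-fold lower number from compound 2 to compound 3 (0.33 log units; beyond the scatter). Compound 1, carrying a plain halogenated aromatic group, also sits below the limit of compound 2. The expectation is therefore a step downwards of modest size, an at least 2.1-fold lower number from compound 2 to compound 4 (0.32 log units; beyond the scatter). Compound 4 is estimated at 9500 nM, within a range of 3500 nM to 26000 nM.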

Compound 4, half-maximal inhibitory concentration: 3470 nM
The estimate for compound 4 lay 2.7-fold (0.44 log units) above the measured number; the measured number lies below the stated range.
By their numbers in this assay, from the lowest: compound 4; then compounds 3 and 1 (each within the scatter of the next). At a limit, above all of these: compound 2.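

In this assay, for the compounds shown here, 3-chloro-4-nitrophenyl on the amide-type nitrogen gives the first steps between two fully measured compounds that lie beyond the scatter: a 2.7-fold lower number from compound 3 to compound 4 (0.43 log units; beyond the scatter) and a 3.4-fold lower number from compound 1 to compound 4 (0.53 log units; beyond the scatter). The groups 3-amino-4-chlorophenyl and 3-chloro-4-nitrophenyl both carry a chlorine and still differ by that step, so a chlorine on the aromatic ring does not by itself fix the number, and the step from the acetamido compound is an at least 5.7-fold lower number from compound 2 to compound 4 (0.76 log units; beyond the scatter). Compound 2 stands at a limit of the assay, so that step gives only a floor and its true size remains unknown: the limit of > 20000 nM in this assay, at which 1 of the 4 values shown sits.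

The compounds shown do not separate what the nitro group contributes from what the chlorine contributes, since no pair differs in only one of these two substituents. They also leave open how a nitrile or a carboxylic acid in place of the nitro group would read in this assay, and whether the step from compound 3 to compound 4 would hold on a core with a longer chain.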